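Carboxymethyl in place of methyl on the amide of compound 1

This account rests on a few compounds, and the source may have more. Where it says the series, first, only, none or still open, it means among the compounds named here.

The series shares one core, seen in compound 1 `CNC(=O)Cn1nc(N)c2c(C(F)(F)F)cc(-c3ccccc3)nc21`. In a functional assay on DU-145 cells (Homo sapiens) for cytotoxicity, read by MTT assay, with a stated time of 24 h (on this read-out lower numbers stand for stronger inhibition and higher numbers for weaker inhibition), compound 1 gives 14400 nM, the highest of the two numbers reported. Compound 3 `Nc1nn(CC(=O)N2CCCCC2)c2nc(-c3ccccc3)cc(C(F)(F)F)c12` gives 3200 nM in this assay, and the step of a 4.5-fold lower number from compound 1 to compound 3 (0.65 log units; beyond the scatter) is the only one measured in this set; it replaces methylamino with piperidin-1-yl on the carbonyl carbon. Compound 2 `Nc1nn(CC(=O)NC2CC2)c2nc(-c3ccccc3)cc(C(F)(F)F)c12`, bearing cyclopropylamino at the same carbon, is reported in this assay as "not active" (no number reported), so no number is available for it.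

Compound 4 `Nc1nn(CC(=O)NCC(=O)O)c2nc(-c3ccccc3)cc(C(F)(F)F)c12` is the next member. It differs from compound 1 by carboxy in place of hydrogen on a saturated chain carbon bound to an amide-type nitrogen, so that methylcarbamoyl becomes (carboxymethyl)carbamoyl. Among the measured compounds shown here, no measured step covers a carboxy group anywhere in this set; the one step that exists concerns the nitrogen substituent of the amide and does not bear on this change. What the data show is that compound 1 and compound 2 both carry small groups on the amide nitrogen and that neither is strong, which gives no reason to expect compound 4 to move toward compound 3. He therefore expects compound 4 to stay near compound 1, with a step of a 1.4-fold higher number from compound 1 to compound 4 (0.14 log units; within the scatter) that need not exceed the scatter, and estimates compound 4 at 20000 nM, within 7000 nM to 60000 nM.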

Compound 4, half-maximal inhibitory concentration: 18800 nM
Beside the measured number, compound 4's estimate is 1.1-fold (0.03 log units) above it; the range from low to high includes it.
By their numbers in this assay, from the lowest: compound 3; then compounds 1 and 4 (each within the scatter of the next).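

In this assay, carboxy in place of hydrogen on a saturated chain carbon bound to an amide-type nitrogen gives a 1.3-fold higher number from compound 1 to compound 4 (0.12 log units; within the scatter), so this read-out does not separate methyl from carboxymethyl on the amide of the shared core, even though the new group brings 3 heavy atoms, a hydrogen-bond donor and a hydrogen-bond acceptor. The piperidin-1-yl amide stays apart from this new compound as well, with a 5.9-fold higher number from compound 3 to compound 4 (0.77 log units; beyond the scatter), so the gap first seen with the methylamino amide also holds for (carboxymethyl)amino, while steps involving compound 2 cannot be read, as it has no number. Nothing measured here accounts for why the number holds at this place when carboxy enters.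

The compounds shown leave open how a methyl ester or a primary amine at the same place would read in this assay, and whether a longer chain ending in a carboxylic acid would read like compound 4. They also leave open whether a carboxylic acid on the piperidine ring would keep the value of compound 3, 3200 nM.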